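Inverting one chain stereocentre of compound 3

A few compounds are considered here, and "the series" means these few. Any claim that something is new, unique, unknown or untested is made for them only; others in the source may bear on it.

In a functional assay on A2780 ADR cells (Homo sapiens) for cytotoxicity, read by MTT assay, with a stated time of 24 h (on this read-out higher numbers stand for weaker inhibition and lower numbers for stronger inhibition), compound 1 (`CCCCC[C@H](C[C@@H](O)C[C@H]1CC=CC(=O)O1)OC`) gives 18100 nM, compound 2 (`CCCCC[C@H](C[C@H](O)C[C@@H]1CC=CC(=O)O1)OC`) gives 30000 nM and compound 3 (`CCCCC[C@@H](C[C@H](O)C[C@H]1CC=CC(=O)O1)OC`) gives 48000 nM. The only gap beyond the scatter is modest: a 2.7-fold higher number from compound 1 to compound 3 (0.42 log units; beyond the scatter). Both a 1.6-fold higher number from compound 2 to compound 3 (0.20 log units; within the scatter) and a 1.7-fold higher number from compound 1 to compound 2 (0.22 log units; within the scatter) stay within the scatter. Compound 3 therefore shares the upper end of the numbers with compound 2.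

Compound 4 (`CCCCC[C@H](C[C@H](O)C[C@H]1CC=CC(=O)O1)OC`) has the same atoms and bonds as compound 3, with the two compounds have the same atoms and bonds and differ only in configuration as drawn: 1 of 3 stereo elements differ; a stereocentre at a saturated chain carbon is drawn S in compound 3 and R in compound 4: a stereocentre at a saturated chain carbon is drawn S in compound 3 and R in compound 4.

Among the measured compounds shown here, no measured step changes a single stereo element. The closest guides are a 2.7-fold higher number from compound 1 to compound 3 (0.42 log units; beyond the scatter) and a 1.6-fold higher number from compound 2 to compound 3 (0.20 log units; within the scatter). Each redraws a saturated chain carbon from R to S, the reverse sense of the change here, but each also alters a second stereocentre. For the measured compounds named here, both are small, so only a small shift towards a lower number is expected in this assay, with no step clearly beyond the scatter. The expected step is a 1.8-fold lower number from compound 3 to compound 4 (0.25 log units; within the scatter). For compound 4 the estimate is 27000 nM, with an expected range from 11000 nM to 60000 nM.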

Compound 4, half-maximal inhibitory concentration: 57500 nM
The estimate for compound 4 lay 2.1-fold (0.33 log units) below the measured number; the range from low to high includes it.
By their numbers in this assay, from the lowest: compounds 1, 2, 3 and 4 (each within the scatter of the next, the first and the last beyond it).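

With compound 4 the series gains its first steps that change a single stereo element, so this assay can now be read one centre at a time. Redrawing a saturated chain carbon from S to R gives a 1.2-fold higher number from compound 3 to compound 4 (0.08 log units; within the scatter), and redrawing a saturated ring carbon from S to R gives a 1.9-fold higher number from compound 2 to compound 4 (0.28 log units; within the scatter), so neither of these two centres, taken alone, moves the number beyond the scatter around compound 4. Only the other saturated chain carbon does so, with a 3.2-fold higher number from compound 1 to compound 4 (0.50 log units; beyond the scatter), a modest step that places the one gap of this series beyond the scatter at a single centre: the fact that compounds 1 and 4 differ only in the configuration as drawn.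

Going by these compounds, whether that modest step at the chain carbon holds with an ethoxy group or a carboxylic acid, or with a longer chain on the shared core, remains open. Also open, on these data alone, is how the three stereo elements act in the combinations absent from these four compounds, and whether the same small steps appear in cells other than those of this one assay.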